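Thiophene-fused series: aryl urea swap at the chain-variant end

This account rests on a few compounds, and the source may have more. Where it says the series, first, only, none or still open, it means among the compounds named here.

Measured so far in a functional assay on MDA-MB-231 cells (Homo sapiens) for cytotoxicity, read by MTT assay, with a stated time of 72 h; a higher number here means a weaker inhibitor, a lower number a stronger inhibitor:
- compound 1 `CN(C)CCCNc1nc(-c2ccc(NC(=O)Nc3ccccc3F)cc2)nc2ccsc12`: 660 nM
- compound 2 `CN(C)CCNc1nc(-c2ccc(NC(=O)Nc3ccc(Cl)cc3Cl)cc2)nc2ccsc12`: 2450 nM
- compound 3 `CCN(CC)CCNc1nc(-c2ccc(NC(=O)Nc3ccccc3F)cc2)nc2ccsc12`: 580 nM

Compound 3 gives the lowest of the three numbers, though the step of a 1.1-fold lower number from compound 1 to compound 3 (0.06 log units; within the scatter) is within the scatter, so compounds 1 and 3 cannot be ordered against each other. Compound 2 stands apart: its value is beyond the scatter from that of compound 3, and compound 2 differs from both compound 1 and compound 3 in two places at once, the aryl group on the urea and the amine-bearing chain.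

Compound 4 `CCN(CC)CCNc1nc(-c2ccc(NC(=O)Nc3ccc(Cl)cc3Cl)cc2)nc2ccsc12` is unmeasured. Relative to compound 3 the change is 2,4-dichlorophenyl in place of 2-fluorophenyl on an amide-type nitrogen. Among the compounds with values here, no single measured step isolates this change. Within the data shown here, the only bearing comes from compound 1 against compound 2, where the 2,4-dichlorophenyl compound shows the higher number, but the chain differs there as well, so the attribution is uncertain. Taking the aryl change as the likelier driver, the expectation for compound 4 in this assay is a higher number than compound 3, with an estimated step of a 3.8-fold higher number from compound 3 to compound 4 (0.58 log units; beyond the scatter). The estimate for compound 4 is 2200 nM, with a range from 1000 nM to 5000 nM.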

Compound 4, half-maximal inhibitory concentration: 2480 nM
For compound 4 the middle estimate is 1.1-fold (0.05 log units) below the measured one; measured number inside the range.
By their numbers in this assay, from the lowest: compounds 3 and 1 (each within the scatter of the next); then compounds 2 and 4 (each within the scatter of the next).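

In this assay, the aryl change on the amide-type nitrogen can now be read alone, with the diethylamino chain held constant: 2,4-dichlorophenyl in place of 2-fluorophenyl gives a step beyond the scatter (a 4.3-fold higher number from compound 3 to compound 4 (0.63 log units; beyond the scatter)). With 2,4-dichlorophenyl held constant, diethylamino in place of dimethylamino gives a step within the scatter (a 1.0-fold higher number from compound 2 to compound 4 (0.01 log units; within the scatter)), so only the aryl change separates compounds in these two single-place comparisons, and the two amines cannot be ordered in this aryl setting. Nothing available bears on what lies behind the aryl step.

From the compounds shown here alone, the step from 2-fluorophenyl to 2,4-dichlorophenyl removes the fluorine and introduces two chlorines at once, so it remains open how much of the step would appear with a single-halogen group such as 2-chlorophenyl or 4-chlorophenyl. Going by these compounds, it is also open whether the chain stays as flat with other aryl groups on the urea, or with a ring amine such as pyrrolidine or morpholine in place of diethylamino.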